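Swapping the terminal heteroaryl ring ahead of a new measurement

This account rests on a few compounds, and the source may have more. Where it says the series, first, only, none or still open, it means among the compounds named here.

Measured so far:
Compound 1 `CCC(C)(C)Cc1c[nH]c(CCc2ccc(-c3ccncc3)cc2)n1`: 101 nM
Compound 2 `CCC(C)(C)Cc1c[nH]c(CCc2ccc(-c3cccc(C#N)n3)cc2)n1`: 140 nM

Both compounds were tested in an in vitro assay on CHO cells for displacement of a labelled ligand from Bombesin receptor subtype-3 (Homo sapiens), read by scintillation counting, with a stated time of 2 h; a higher number here means a weaker inhibitor, a lower number a stronger inhibitor. Compound 1 gives 101 nM in this assay, and compound 2 gives 140 nM. Of the two numbers compound 2 has the higher one, but the gap, a 1.4-fold higher number from compound 1 to compound 2 (0.14 log units; within the scatter), is within the scatter, so the two compounds cannot be told apart on these data.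

Compound 3 `CCC(C)(C)Cc1c[nH]c(CCc2ccc(-c3cnsc3)cc2)n1` has not been measured yet. It differs from compound 2 in one place: 1,2-thiazol-4-yl in place of 6-cyanopyridin-2-yl on an aromatic carbon. Among the measured compounds shown here, the single measured step that bears on this position, from compound 1 to compound 2, exchanged one six-membered heteroaryl ring for another and stayed within the scatter. For the measured compounds named here, with only that comparison available, there is no ground to expect the move to the five-membered ring to shift the number beyond the scatter in either direction. The expected step from compound 2 is therefore small: a 1.1-fold higher number from compound 2 to compound 3 (0.03 log units; within the scatter). For compound 3 the estimated value in this assay is 150 nM, with a range from 50 nM to 450 nM.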

Compound 3, half-maximal inhibitory concentration: 10 nM
Compound 3: middle estimate off by 15-fold (1.18 log units), on the high side; measured number below the stated range.
By their numbers in this assay, from the lowest: compound 3; then compounds 1 and 2 (each within the scatter of the next).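

At this position the identity of the terminal ring clearly matters in this assay: the 1,2-thiazol-4-yl group gives a 14-fold lower number from compound 2 to compound 3 (1.15 log units; beyond the scatter) and also a 10-fold lower number from compound 1 to compound 3 (1.00 log units; beyond the scatter) as a second comparison, both beyond the scatter, whereas the two six-membered rings of compound 1 and compound 2 could not be told apart. Compound 3 is therefore the strongest inhibitor of the three, and the earlier pair gave no sign that a change at this aromatic carbon could move the number this far. Nothing available here gives a measured explanation for the size of this step.

The change replaces a six-membered ring with a five-membered one and also brings in sulfur, so the compounds shown leave open whether ring size, the sulfur or the placement of the ring nitrogen accounts for the lower number. A thiophen-3-yl group, which keeps the sulfur in a five-membered ring without the nitrogen, or a 1,2-thiazol-5-yl group, which keeps the same ring but joins it through a different carbon, would help separate these possibilities.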